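The compounds below may be only part of what the source reports. "The series", "measured", "known", "first", "only" and "open" are said of these compounds alone.

Measured compounds:
compound 1 `CCOC(=O)C1=C(Nc2ccc(OC)cc2)S/C(=C\c2ccc[nH]2)C1=O`: 27.6%
compound 2 `CCOC(=O)C1=C(Nc2ccc(OC)c(OC)c2)S/C(=C\c2ccc[nH]2)C1=O`: 47.9%

In a functional assay on JAR cells (Homo sapiens) for inhibition, read by MTT assay, with a stated time of 72 h, tested at 10 uM (a lower number here means less inhibition, a higher number more inhibition at the concentration tested (going by the name of the read-out)), compound 1 stands at the lower of the two numbers; the nearest is compound 2, reached through a number 20.3 percentage points higher from compound 1 to compound 2 (beyond the scatter), a change described as methoxy in place of hydrogen on an aromatic carbon. Compound 3 `CCOC(=O)C1=C(Nc2ccccc2Br)S/C(=C\c2ccc[nH]2)C1=O` is not yet measured and differs from compound 1 as follows: 2-bromophenyl in place of 4-methoxyphenyl on an amine nitrogen. Among the compounds with values here, no measured step touches a bromine or the removal of the methoxy, so no step bears directly on this change; the single step from compound 1 to compound 2 only shows that changing the ring on the amine nitrogen can move the result modestly. Accordingly the step of a number 4.4 percentage points higher from compound 1 to compound 3 (within the scatter) is expected to stay within the scatter, with no confident direction. Compound 3 is estimated at 32%, within a range of 10% to 58%.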

Compound 3, a percentage reported as inhibition, at one concentration (the size of the read-out at that concentration, not a potency): 62.7%
Estimate against measurement, compound 3: 30.7 percentage points below; the measured number lies above the stated range.
By their numbers in this assay, from the lowest: compound 1; then compound 2; then compound 3.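

In this assay, within the data shown here, the group on the amine nitrogen turns out to move the result much further than the earlier pair showed: 2-bromophenyl in place of 4-methoxyphenyl gives a large step (a number 35.1 percentage points higher from compound 1 to compound 3 (beyond the scatter)), whereas the only earlier step was modest (a number 20.3 percentage points higher from compound 1 to compound 2 (beyond the scatter)). A higher number at this position therefore does not require a methoxy on the aromatic ring, since 2-bromophenyl carries none. This one change removes the methoxy and brings in the bromine together, so their shares cannot be separated, and nothing measured here accounts for the gain.

The compounds shown leave open whether a chlorine or a methyl in place of the bromine would give a similar number. They also leave open how a carboxylic acid in place of the ethyl ester would fare.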